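Fluorine placement on a biaryl sulfonamide series

A few compounds are considered here, and "the series" means these few. Any claim that something is new, unique, unknown or untested is made for them only; others in the source may bear on it.

Measured compounds in a functional assay on J774 cells (Mus musculus) for cytotoxicity, read by resazurin assay, with a stated time of 72 h; on this read-out higher numbers stand for weaker inhibition and lower numbers for stronger inhibition:
compound 1, `O=S(=O)(Nc1ccc(CO)c(CO)c1)c1ccc(-c2ccc(F)cc2)cc1`, gives 1000 nM
compound 2, `O=S(=O)(Nc1ccc(CO)c(CO)c1)c1ccc(-c2ccc(F)cc2F)cc1`, gives 150 nM
compound 3, `O=S(=O)(Nc1cccc(CO)c1)c1ccc(-c2ccccc2F)cc1`, gives 1300 nM

Compound 1 and compound 2 share a core and differ in one place: fluoro in place of hydrogen on an aromatic carbon. That change brought a 6.7-fold lower number from compound 1 to compound 2 (0.82 log units; beyond the scatter). The place of the change in this pair is described as ortho to a large group and meta to a fluoro group.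

Compound 3 carries a different core; the difference between the core of compound 3 and the core of compound 1 is not broken down here. Compound 3 and compound 1 give numbers within the usual scatter of each other, so no order between them is claimed. Compound 2 stands beyond the scatter from both.

Compound 4, `O=S(=O)(Nc1cccc(CO)c1)c1ccc(-c2ccc(F)cc2F)cc1`, has not yet been measured. It differs from compound 3 in one place: fluoro in place of hydrogen on an aromatic carbon. This is the same kind of change as that from compound 1 to compound 2, but its surroundings read differently: here the place is meta to a fluoro group and para to a large group, where in the earlier pair it was ortho to a large group and meta to a fluoro group.

For the measured compounds named here, only one example of this kind of change has been measured, so the expectation rests on a single step. For compound 4 in this assay the expected step is a 4.3-fold lower number from compound 3 to compound 4 (0.64 log units; beyond the scatter), somewhat smaller than the measured step because the earlier one, a 6.7-fold lower number from compound 1 to compound 2 (0.82 log units; beyond the scatter), came from a place described in different words. Compound 4 is estimated at 300 nM, with a likely range from 120 nM to 900 nM.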

Compound 4, half-maximal inhibitory concentration: 300 nM
Beside the measured number, compound 4's estimate shows no gap at the digits printed, within the range that was stated.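

In this assay the fluoro entering para to a large group gives a 4.3-fold lower number from compound 3 to compound 4 (0.64 log units; beyond the scatter), and this agrees with the step seen on the other core: the same change on two cores in this assay, a 6.7-fold lower number (0.82 log units; beyond the scatter) from compound 1 to compound 2 and a 4.3-fold lower number (0.64 log units; beyond the scatter) from compound 3 to compound 4, 1.5-fold (0.19 log units) apart, within the scatter of two such steps

With hydrogen in place of hydroxymethyl, the core difference gives a 2.0-fold higher number from compound 2 to compound 4 (0.30 log units; within the scatter), so the two cores are not told apart once both carry the 2,4-difluorophenyl group. For the compounds shown here, the fluoro step therefore carries over between these two cores, but this does not amount to a rule for the series: only two pairs stand here, both end in the 2,4-difluorophenyl group, and the place where the fluoro enters differs between them along with the core, so the contributions of place and core cannot be separated.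

Open questions remain on both sides of the sulfonamide. A 4-fluorophenyl group on the core of compound 3 would separate place from core, while chloro or methoxy in place of the entering fluoro, and an amine, a carboxylic acid or a longer chain in place of hydroxymethyl, would test how far the step holds beyond these compounds.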